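The source may hold more compounds than are shown below. What is called first, only, known or untested is meant among the compounds shown, and "the series" means these compounds.

Of the compounds shown here, three have been measured in a functional assay on HT-29 cells (Homo sapiens) for antiproliferative activity, read by MTT assay, with a stated time of 72 h; a lower number here means a stronger inhibitor, a higher number a weaker inhibitor. Compound 1 `O=C(Nc1ccc(Oc2ccnc3[nH]ccc23)cc1)c1cc2cccnc2n(-c2ccccc2)c1=O` gives 290 nM; compound 2 `O=C(Nc1ccc(Oc2ccnc3[nH]ccc23)cc1)c1cc2cccnc2n(-c2ccc(Cl)cc2)c1=O` gives 280 nM; compound 3 `Cn1ccc2c(Oc3ccc(NC(=O)c4cc5cccnc5n(-c5ccccc5)c4=O)cc3)ccnc21` gives 620 nM, the highest of the three numbers, with a 2.1-fold higher number from compound 1 to compound 3 (0.33 log units; beyond the scatter). Compound 4 `COc1ccc(-n2c(=O)c(C(=O)Nc3ccc(Oc4ccnc5c4ccn5C)cc3)cc3cccnc32)cc1` differs from compound 3 by methoxy in place of hydrogen on an aromatic carbon. Going by the values given here, the one measured step that bears on this position is a 1.0-fold lower number from compound 1 to compound 2 (0.02 log units; within the scatter), a substituent on the same ring that left the number essentially unchanged. On that basis the step expected for compound 4 is small, a 1.0-fold lower number from compound 3 to compound 4 (0.01 log units; within the scatter), with no direction beyond the scatter. Compound 4 is therefore estimated at 600 nM, within a range of 250 nM to 1500 nM.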

Compound 4, half-maximal inhibitory concentration: 2050 nM
Estimate against measurement, compound 4: 3.4-fold (0.53 log units) below; the measured number lies above the stated range.
By their numbers in this assay, from the lowest: compounds 2 and 1 (each within the scatter of the next); then compound 3; then compound 4.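

In this assay this position does not tolerate every substituent: phenyl to 4-methoxyphenyl gives a 3.3-fold higher number from compound 3 to compound 4 (0.52 log units; beyond the scatter), whereas chloro on the same ring gave a 1.0-fold lower number from compound 1 to compound 2 (0.02 log units; within the scatter). These two steps differ in both the entering group and the core carrying it, so the contrast cannot be assigned to methoxy alone. No available evidence accounts for the methoxy step.

On these data alone, it remains open whether methoxy gives a similar step on the core of compound 1. Also open, as far as these compounds go, is how a hydroxyl, an amine or a carboxylic acid would behave at this place.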